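A few compounds are considered here, and "the series" means these few. Any claim that something is new, unique, unknown or untested is made for them only; others in the source may bear on it.

Series notes. Compound 1 `CC(C)N(Cc1cccc(OCCCCCC(=O)O)c1)C(=O)c1ccc(-c2cccc(OCc3ccccc3)c2)cc1`, compound 2 `Cc1nnc(-c2cccc(-c3ccc(C(=O)N(Cc4cccc(OCCCCCC(=O)O)c4)C(C)C)cc3)c2)o1` and compound 3 `CCOC(=O)CCCCCOc1cccc(CN(C(=O)c2ccc(-c3cnc(OC)nc3OC)cc2)C(C)C)c1` share a common core and have been run in an ADME assay on HEK293 cells (Homo sapiens) for cytotoxicity, read by CellTiter-Glo and resazurin assay, with a stated time of 72 h; on this read-out higher numbers stand for an effect only at larger amounts of compound and lower numbers for an effect already at smaller amounts. In this assay compound 1 gives > 26000 nM, which is a limit of the assay and not a number. In this assay compound 2 gives > 26000 nM, likewise a limit. In this assay compound 3 gives > 26000 nM, again a limit. The step that the two limits leave unreadable from compound 1 to compound 2 is therefore unreadable, since both of its ends sit at the limit (the limit of > 26000 nM in this assay, at which 3 of the 3 values shown sit). Compound 3 thus stands where every measured value in the set stands, at the limit, with no number to rank it against the others.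

Compound 4 `CCOC(=O)CCCCCOc1cccc(CN(C(=O)c2ccc(-c3cc(F)cc(OC)c3)cc2)C(C)C)c1` remains to be measured. It differs from compound 3 in one place: 3-fluoro-5-methoxyphenyl in place of 2,4-dimethoxypyrimidin-5-yl on an aromatic carbon. Within the data shown here, no measured step covers this change, and the single measured step, a step that the two limits leave unreadable from compound 1 to compound 2, gives no readable size. With all three values sitting at the limit (the limit of > 26000 nM in this assay, at which 3 of the 3 values shown sit), nothing in the set points to a step beyond the scatter in either direction. For compound 4 in this assay the expected step is therefore a number no higher from compound 3 to compound 4 (the limit leaves the size open), that is none beyond the scatter, and a limit rather than a number is expected again. Compound 4 is estimated at 26000 nM, with a range from 13000 nM to 60000 nM.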

Compound 4, half-maximal effective concentration: > 26000 nM
Compound 4: a limit, no number; the forecaster's own chance of this, stated with the estimate: 85%; the middle value lies on the limit itself.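

In this assay compound 4 gives > 26000 nM, a limit and not a number. Compound 3 sits at the same limit, so no step can be read between compound 3 and compound 4. The compounds shown leave open whether any of these changes moves the read-out at all, with no number to rank them: the limit of > 26000 nM in this assay, at which 4 of the 4 values shown sit.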